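Notes on the aryl triazole variation toward compound 4

A few compounds are considered here, and "the series" means these few. Any claim that something is new, unique, unknown or untested is made for them only; others in the source may bear on it.

Going by the values given here, compound 1 `N#CC1=C(N)Oc2c(c3nc4ccccc4nc3c3ccccc23)C12C(=O)N(Cc1cnnn1-c1ccc(Br)cc1)c1ccccc12` is the one member of this set with a number in a functional assay on A549 cells (Homo sapiens) for antiproliferative activity, read by MTT assay, with a stated time of 48 h; a lower number here means a stronger inhibitor, a higher number a weaker inhibitor: compound 1 gives 44300 nM. Compound 2 `COc1ccc(-n2nncc2CN2C(=O)C3(C(C#N)=C(N)Oc4c3c3nc5ccccc5nc3c3ccccc43)c3ccccc32)cc1` sits at a limit of the assay, given for compound 2 as > 50000 nM. Compound 3 `COc1ccccc1-n1nncc1CN1C(=O)C2(C(C#N)=C(N)Oc3c2c2nc4ccccc4nc2c2ccccc32)c2ccccc21` also sits at a limit, given for compound 3 as > 50000 nM. The step of an at least 1.1-fold higher number from compound 1 to compound 2 (0.05 log units; that floor lies within the scatter) and the step of an at least 1.1-fold higher number from compound 1 to compound 3 (0.05 log units; that floor lies within the scatter) are read against (the limit of > 50000 nM in this assay, at which 2 of the 3 values shown sit), and the step that the two limits leave unreadable from compound 2 to compound 3 cannot be sized. Compound 1 thus stands as the single number shown, with both measured steps away from it ending at the limit and neither beyond the scatter.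

Compound 4 `Cc1ccc(-n2nncc2CN2C(=O)C3(C(C#N)=C(N)Oc4c3c3nc5ccccc5nc3c3ccccc43)c3ccccc32)c(C)c1` differs from compound 1 as follows: 2,4-dimethylphenyl in place of 4-bromophenyl on an aromatic nitrogen. Both measured changes at this aromatic nitrogen end at the limit, and the 2,4-dimethylphenyl group is a change of the same kind, so in this assay a small step upward, or none beyond the scatter, is expected. Compound 4 is expected to give about 50000 nM, between 25000 nM and 100000 nM. The expected step is a 1.1-fold higher number from compound 1 to compound 4 (0.05 log units; within the scatter).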

Compound 4, half-maximal inhibitory concentration: > 50000 nM
Compound 4 gave a limit, no number (the forecaster's own chance of this, stated with the estimate: 50%); the middle value sits exactly at the limit.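

In this assay, 2,4-dimethylphenyl in place of 4-bromophenyl on the aromatic nitrogen gives an at least 1.1-fold higher number from compound 1 to compound 4 (0.05 log units; that floor lies within the scatter), a reading that rests on a limit and not on a number. Going by these compounds alone, with methyl groups on the aryl ring as well as methoxy, the 4-bromophenyl of compound 1 remains the only group at this position with a number, and the series now meets a single ceiling: the limit of > 50000 nM in this assay, at which 3 of the 4 values shown sit. The steps among compound 2, compound 3 and compound 4 cannot be read, all three being limits.

Going by these compounds, whether compound 1 truly differs from these three beyond the scatter stays open. Also open, on these data alone, is whether an aryl ring bearing an amine or a carboxylic acid, or a 4-chlorophenyl group, would give a number in this assay.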